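Isopropyl for 1-Methylpiperidin-4-yl on a Benzophenone Benzimidazole Series

The source may report more compounds than this note shows. Statements on the series, on what has been measured and on what is new or still open speak of the compounds shown alone.

Measured so far:
compound 1, `O=C(c1ccccc1)c1ccc2nc(NCCO)[nH]c2c1`: > 30000 nM
compound 2, `O=C(CCCC1CCNCC1)Nc1nc2ccc(C(=O)c3ccccc3)cc2[nH]1`: > 30000 nM
compound 3, `CN1CCC(Cn2c(N)nc3ccc(C(=O)c4ccccc4)cc32)CC1`: > 30000 nM

Of the compounds shown here, three sharing a core have been tested in an ADME assay on CRL8155 cells (Homo sapiens) for cytotoxicity, read by resazurin assay, with a stated time of 72 h; on this read-out lower numbers stand for an effect already at smaller amounts and higher numbers for an effect only at larger amounts of compound. In this assay compound 1 gives > 30000 nM, which is a limit of the assay and not a number. Compound 2 gives > 30000 nM, again a limit rather than a number. Compound 3 gives > 30000 nM, also a limit. Compound 3 therefore stands where every other compound stands: at the limit of > 30000 nM in this assay, at which 3 of the 3 values shown sit. Among the measured compounds shown here, no step between two measured compounds can be read from these values, and no compound can be ranked against another.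

Compound 4, `CC(C)Cn1c(N)nc2ccc(C(=O)c3ccccc3)cc21`, has not yet been measured in this assay. It differs from compound 3 by one change: isopropyl in place of 1-methylpiperidin-4-yl on a saturated chain carbon bound to an aromatic nitrogen.

For the measured compounds named here, nothing among the measured compounds shows that a change at this place moves the read-out, and all three values sit at the same limit. The step from compound 3 to compound 4 is therefore expected to be none beyond the scatter, and most likely compound 4 will again return only a limit. The step this estimate means is a number no higher from compound 3 to compound 4 (the limit leaves the size open), which is expected to fall within the scatter. For compound 4 the estimated value is 30000 nM, with a range from 15000 nM to 100000 nM.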

Compound 4, half-maximal effective concentration: > 30000 nM
Compound 4 gave a limit, no number (the forecaster's own chance of this, stated with the estimate: 80%); the middle value sits exactly at the limit.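

Compound 3 and compound 4 each return only a limit and no number in this assay, so no step can be read between them: the limit of > 30000 nM in this assay, at which 4 of the 4 values shown sit.

The compounds shown leave open whether any compound with the shared core gives a number in this assay, and whether isopropyl in place of 1-methylpiperidin-4-yl moves the read-out at all.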